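This account rests on a few compounds, and the source may have more. Where it says the series, first, only, none or still open, it means among the compounds named here.

Compound 2 `CC(C)C[C@H](N)c1cc(C(F)(F)F)ccc1N1CCN(C(=O)CCc2ccc(O)cc2)CC1` stands at the edge of an assay on HEK293 cells for displacement of a labelled ligand from Melanocortin receptor 4 (Homo sapiens); on this read-out higher numbers stand for weaker inhibition and lower numbers for stronger inhibition: in this assay compound 2 gives > 10000 nM, which is a limit of the assay rather than a number. Compound 3 `CC(C)C[C@H](N)c1cc(C(F)(F)F)ccc1N1CCN(C(=O)CCc2csc3ccccc23)CC1` differs from it by 1-benzothiophen-3-yl in place of 4-hydroxyphenyl on a saturated chain carbon, two bonds along the chain from a carbonyl carbon. Going by the values given here, the only measured step that touches this place is an at least 4.7-fold higher number from compound 1 to compound 2 (0.67 log units; beyond the scatter), in which compound 1 `Cc1cccc(CCC(=O)N2CCN(c3ccc(C(F)(F)F)cc3[C@@H](N)CC(C)C)CC2)c1` gives 2100 nM and the 4-hydroxyphenyl arrives; here it departs again, so a move toward lower numbers is expected, its size uncertain. Compound 3 is therefore estimated at 3000 nM, between 800 nM and 15000 nM. This amounts to an expected step of an at least 3.3-fold lower number from compound 2 to compound 3 (0.52 log units; beyond the scatter).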

Compound 3, inhibition constant: 2300 nM
Beside the measured number, compound 3's estimate is 1.3-fold (0.12 log units) above it; low and high end bracket the measured number.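

In this assay compound 2 gives > 10000 nM, which is a limit of the assay and not a number. Replacing 4-hydroxyphenyl with 1-benzothiophen-3-yl gives an at least 4.3-fold lower number from compound 2 to compound 3 (0.63 log units; beyond the scatter), so the position accepts a larger group with two aromatic rings. Set against 3-methylphenyl, the same group gives a 1.1-fold higher number from compound 1 to compound 3 (0.04 log units; within the scatter), so these two different aromatic groups sit level and only the 4-hydroxyphenyl compound stands apart.

Still open, as far as these compounds go, is whether the hydroxyl alone sets compound 2 apart, which a 4-methoxyphenyl or plain phenyl group here would address, and what a longer chain would do.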